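The source may report more compounds than this note shows. Statements on the series, on what has been measured and on what is new or still open speak of the compounds shown alone.

Working notes on the series, read in a functional assay on HEK293 cells (Homo sapiens) for cytotoxicity (on this read-out lower numbers stand for higher toxicity in this test and higher numbers for lower toxicity in this test), throughout. Compound 1 (`COc1ccc([C@H]2CC(=O)N(Cc3cccc([N+](=O)[O-])c3)C2)cc1OC1CCCC1`) sits at a limit (> 10000 nM) and gives no number. Compound 2 (`COc1ccc([C@H]2CC(=O)N(c3cc(N)cc(F)c3)C2)cc1OC1CCCC1`) also sits at a limit (> 10000 nM) of the assay. Compound 3 (`COc1ccc([C@H]2CC(=O)N(c3ccc(C)cc3)C2)cc1OC1CCCC1`), the starting point of this step, likewise reports only a limit (> 10000 nM) and has no number. Going by the values given here, every value so far stands at the same place (the limit of > 10000 nM in this assay, at which 3 of the 3 values shown sit) on the scale.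

The change to compound 4 (`COc1ccc([C@H]2CC(=O)N(c3ccccn3)C2)cc1OC1CCCC1`) is pyridin-2-yl in place of 4-methylphenyl on an amide-type nitrogen in a ring.

Among the compounds with values here, three measured steps bear on it, all at that same nitrogen: (a step that the two limits leave unreadable from compound 1 to compound 2), (a step that the two limits leave unreadable from compound 1 to compound 3) and (a step that the two limits leave unreadable from compound 2 to compound 3). None of them has a readable size, so they give no direction. Within the data shown here, they show only that compound 1, compound 2 and compound 3 share the one limit (the limit of > 10000 nM in this assay, at which 3 of the 3 values shown sit) in this assay despite their different groups, and no compound so far goes against this. No step beyond the scatter is therefore expected, and no direction is expected either.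

The step expected here is (a step that the limit leaves unreadable from compound 3 to compound 4) and it is an estimate. Compound 4 is estimated at (15000 nM) with an expected range from (10000 nM) to (40000 nM), and a report of only a limit is the likeliest outcome.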

Compound 4, half-maximal cytotoxic concentration: > 10000 nM
Compound 4 was reported as a limit (the forecaster's own chance of this, stated with the estimate: 90%); the middle value lies beyond the limit too.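

In this assay compound 4 gives > 10000 nM, which is a limit and not a number. Its steps from compound 1, compound 2 and compound 3 therefore cannot be read, as all four compounds share one position: the limit of > 10000 nM in this assay, at which 4 of the 4 values shown sit.

The compounds shown leave open whether any group on the amide-type nitrogen in a ring changes cytotoxicity in this assay.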